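Extending a small chain from methyl to ethyl on two different cores

This account rests on a few compounds, and the source may have more. Where it says the series, first, only, none or still open, it means among the compounds named here.

Compound 1 `CNCC(=O)Nc1cc(OC)ccc1C(=O)c1ccc2c(c1)C=CC(C)(C)O2` and compound 2 `CCNCC(=O)Nc1cc(OC)ccc1C(=O)c1ccc2c(c1)C=CC(C)(C)O2` share one core. In a functional assay on HeLa cells (Homo sapiens) for antiproliferative activity, read by MTT assay, with a stated time of 48 h (on this read-out lower numbers stand for stronger inhibition and higher numbers for weaker inhibition), compound 1 gives 970 nM and compound 2 gives 3110 nM. The change between them is methyl in place of hydrogen on a saturated chain carbon bound to an amine nitrogen and it produced a 3.2-fold higher number from compound 1 to compound 2 (0.51 log units; beyond the scatter). Compound 3 `C=C(c1cc(OC)c(OC)c(OC)c1)c1ccc(OC)c(O)c1NC(=O)COC` is built on a different core; the difference between the two cores is not broken down here. In this assay compound 3 gives 330 nM. Compound 4 `C=C(c1cc(OC)c(OC)c(OC)c1)c1ccc(OC)c(O)c1NC(=O)COCC` has not yet been measured. It differs from compound 3 by methyl in place of hydrogen on a saturated chain carbon bound to an oxygen on a saturated carbon. For the measured compounds named here, this is the same kind of change as the one from compound 1 to compound 2, but the place is not the same: there the carbon was bound to an amine nitrogen, here it is bound to an oxygen on a saturated carbon. Because the earlier step of a 3.2-fold higher number from compound 1 to compound 2 (0.51 log units; beyond the scatter) weakened activity only modestly, a similar or smaller loss is expected here, giving an estimated step of a 2.0-fold higher number from compound 3 to compound 4 (0.29 log units; within the scatter). Compound 4 is therefore expected to give about 650 nM, in the range 250 nM to 1800 nM.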

Compound 4, half-maximal inhibitory concentration: 690 nM
Estimate against measurement, compound 4: 1.1-fold (0.03 log units) below; the measured number falls inside the stated range.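

In this assay, the added methyl gives a 2.1-fold higher number from compound 3 to compound 4 (0.32 log units; beyond the scatter). The same change raises the number on both cores, and the two steps agree in size: the same change on two cores in this assay, a 3.2-fold higher number (0.51 log units; beyond the scatter) from compound 1 to compound 2 and a 2.1-fold higher number (0.32 log units; beyond the scatter) from compound 3 to compound 4, 1.5-fold (0.19 log units) apart, within the scatter of two such steps. For the compounds shown here, this shows that the modest loss carried over between these two cores, but it rests on only two pairs and the place differs, a carbon bound to an amine nitrogen in one and a carbon bound to an oxygen on a saturated carbon in the other; it gives neither a rule for the whole series nor a reason for the loss.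

The compounds shown leave open whether a longer chain, such as propoxy in place of ethoxy, would raise the number further. From the compounds shown here alone, how a hydroxyl or an amine in place of the added methyl would behave on either core also remains open.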